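Second Chloro on the Fused Core Is Expected to Transfer

A few compounds are considered here, and "the series" means these few. Any claim that something is new, unique, unknown or untested is made for them only; others in the source may bear on it.

Compound 1 `ClCc1cccc(Cn2cnc3ncnc(Cl)c32)c1`: 15100 nM
Compound 2 `ClCc1ccccc1Cn1cnc2ncnc(Cl)c21`: 2230 nM
Compound 3 `ClCc1cccc(Cn2cnc3nc(Cl)nc(Cl)c32)c1`: 410 nM

All three were measured in a functional assay on SW-620 cells (Homo sapiens) for cytotoxicity, read by sulforhodamine B assay, with a stated time of 48 h; on this read-out higher numbers stand for weaker inhibition of growth and lower numbers for stronger inhibition of growth. Compound 1 and compound 2 are built from the same atoms joined differently; the difference between the two cores is not broken down here, and their values simply show that compound 2 gives the lower number in this assay. From compound 1 to compound 3 the change is chloro in place of hydrogen on an aromatic carbon, and it gave a 37-fold lower number from compound 1 to compound 3 (1.57 log units; beyond the scatter). Compound 4 `ClCc1ccccc1Cn1cnc2nc(Cl)nc(Cl)c21` has not yet been measured; it differs from compound 2 by chloro in place of hydrogen on an aromatic carbon, the same change at the same place. Because a 37-fold lower number from compound 1 to compound 3 (1.57 log units; beyond the scatter) was large, a step of similar direction is expected for compound 4, estimated as a 22-fold lower number from compound 2 to compound 4 (1.35 log units; beyond the scatter). The value expected for compound 4 in this assay is 100 nM, most likely between 25 nM and 400 nM.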

Compound 4, concentration for 50% growth inhibition: 260 nM
Estimate against measurement, compound 4: 2.6-fold (0.41 log units) below, within the range that was stated.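

In this assay, chloro in place of hydrogen on an aromatic carbon gave an 8.6-fold lower number from compound 2 to compound 4 (0.93 log units; beyond the scatter). The direction of the change carried over from one core to the other, but its size did not: the same change on two cores in this assay, a 37-fold lower number (1.57 log units; beyond the scatter) from compound 1 to compound 3 and an 8.6-fold lower number (0.93 log units; beyond the scatter) from compound 2 to compound 4, 4.3-fold (0.63 log units) apart, beyond the scatter of two such steps. This pair of cores shows only that the sign held in these compounds; it does not show why the sizes differ or how large the step would be on a further core.

The compounds shown leave open whether a different group on that carbon between two ring nitrogen atoms, such as an amine or a methoxy group, would also lower the number. They also leave open whether any such step would hold in other cell lines.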